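The compounds below may be only part of what the source reports. "The series", "measured", "known", "first", "only" and "open" are said of these compounds alone.

Working notes on the series. In a functional assay on MCF7 cells (Homo sapiens) for cytotoxicity, read by MTT assay, with a stated time of 48 h (on this read-out lower numbers stand for stronger inhibition and higher numbers for weaker inhibition), compound 1 `C=C1CCC[C@]2(C)CCC(C=O)=CC[C@@]12C` gives 319000 nM. Compound 2 `CC1(C)CCCC2=CC=C(C=O)CC[C@]21C` gives 167000 nM. Only these two numbers exist so far, and they lie within the usual scatter of each other, so they set no order. Within the data shown here, compound 1 therefore stands level with the only other measured compound. Among the measured compounds shown here, the two compounds also differ in more than one place, so no measured step between compounds is available to guide the next one.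

The next compound is compound 3 `C#CC1=CC[C@@]2(C)C(=C)CCC[C@]2(C)CC1`, which carries ethynyl in place of formyl on a double-bonded ring carbon of the core of compound 1: ethynyl in place of formyl on a double-bonded ring carbon. For the measured compounds named here, no measured pair shows what this exchange does in this assay, so the expectation is anchored on compound 1 at 319000 nM and stays close to it. No step beyond the scatter is expected in either direction. The estimated step is a 1.5-fold lower number from compound 1 to compound 3 (0.16 log units; within the scatter). Compound 3 is expected at about 220000 nM, with an estimated range of 80000 nM to 500000 nM.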

Compound 3, half-maximal inhibitory concentration: 575000 nM
Estimate against measurement, compound 3: 2.6-fold (0.42 log units) below, outside the stated range (above it).
By their numbers in this assay, from the lowest: compounds 2, 1 and 3 (each within the scatter of the next, the first and the last beyond it).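

Among these compounds, this is the first measured step at this position: on the double-bonded ring carbon of the seven-membered ring, ethynyl in place of formyl gives a 1.8-fold higher number from compound 1 to compound 3 (0.26 log units; within the scatter) in this assay and so leaves the two compounds level. The exchange replaces a double bond outside aromatic rings and a hydrogen-bond acceptor with a triple bond and no such acceptor, yet the read-out does not separate compound 1 from compound 3, so formyl is not shown to be needed at this place on this core. No measured information bears on why the two compounds stand level.

Going by these compounds, whether any group at this ring carbon can move the number beyond the scatter stays open, and a carboxylic acid, an amine or a longer chain in place of formyl would put that to a direct test. Also open, on these data alone, is whether ethynyl in place of formyl behaves the same way on the core of compound 2, since the step at hand comes from a single pair on the core of compound 1.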